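Trifluoromethyl position on the third aryl ring of the pyridine series

The source may report more compounds than this note shows. Statements on the series, on what has been measured and on what is new or still open speak of the compounds shown alone.

Compound 3 `Oc1ccc(-c2cc(-c3ccccc3C(F)(F)F)cc(-c3cccc(O)c3)n2)cc1` gives 2750 nM in a functional assay on DU-145 cells (Homo sapiens) for inhibition (on this read-out lower numbers stand for stronger inhibition and higher numbers for weaker inhibition), which places it second highest of the three numbers recorded: indistinguishable from compound 1 `Oc1ccc(-c2cc(-c3cccc(F)c3)cc(-c3cccc(O)c3)n2)cc1` at 2700 nM, and well separated from compound 2 `Oc1ccc(-c2cc(-c3ccc(F)cc3)cc(-c3cccc(O)c3)n2)cc1` at 15200 nM. The change to compound 4 `Oc1ccc(-c2cc(-c3cccc(C(F)(F)F)c3)cc(-c3cccc(O)c3)n2)cc1` is 3-(trifluoromethyl)phenyl in place of 2-(trifluoromethyl)phenyl on an aromatic carbon. Going by the values given here, two measured steps bear on it. The step of a 5.6-fold higher number from compound 1 to compound 2 (0.75 log units; beyond the scatter) shows that moving a fluorine from the 3-position to the 4-position costs potency, whereas the step of a 1.0-fold higher number from compound 1 to compound 3 (0.01 log units; within the scatter) shows that a 3-fluorophenyl and a 2-(trifluoromethyl)phenyl give the same result. The step of a 5.5-fold lower number from compound 2 to compound 3 (0.74 log units; beyond the scatter) restates the same gap from the other side. Among the compounds with values here, a 3-(trifluoromethyl)phenyl has no direct precedent here, but the substituent positions that have already been tolerated, the 3-position for fluorine and the 2-position for trifluoromethyl, suggest the step of a 1.1-fold lower number from compound 3 to compound 4 (0.04 log units; within the scatter) is expected to fall within the scatter. Compound 4 is therefore estimated at 2500 nM, with a range of 800 nM to 8000 nM.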

Compound 4, half-maximal inhibitory concentration: 11100 nM
The estimate for compound 4 lay 4.4-fold (0.65 log units) below the measured number, outside the stated range (above it).
By their numbers in this assay, from the lowest: compounds 1 and 3 (each within the scatter of the next); then compounds 4 and 2 (each within the scatter of the next).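

In this assay, where the trifluoromethyl group sits on this aryl ring matters: 3-(trifluoromethyl)phenyl in place of 2-(trifluoromethyl)phenyl gives a 4.0-fold higher number from compound 3 to compound 4 (0.61 log units; beyond the scatter). Trifluoromethyl in place of fluoro gives a 4.1-fold higher number from compound 1 to compound 4 (0.61 log units; beyond the scatter), so the low number seen with 3-fluorophenyl does not carry over to 3-(trifluoromethyl)phenyl, while a 1.4-fold lower number from compound 2 to compound 4 (0.14 log units; within the scatter) leaves 3-(trifluoromethyl)phenyl and 4-fluorophenyl indistinguishable. Nothing available explains these steps.

Still open, as far as these compounds go, is how 2-fluorophenyl and 4-(trifluoromethyl)phenyl would read on this ring position, which would complete the comparison of positions for both groups. Also open, from the compounds shown here alone, is whether an aryl ring carrying an amine or a carboxylic acid would match compound 1 and compound 3 or fall with compound 2 and compound 4.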